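Swapping thiophen-2-yl for ethynyl at the assay limit

A few compounds are considered here, and "the series" means these few. Any claim that something is new, unique, unknown or untested is made for them only; others in the source may bear on it.

In a functional assay on HeLa S3 cells (Homo sapiens) for antiproliferative activity, read by XTT assay, with a stated time of 72 h (on this read-out higher numbers stand for weaker inhibition and lower numbers for stronger inhibition), compound 3 (`Cc1nc(N)c2c(-c3cccs3)cn([C@@H]3O[C@H](CO)[C@@H](O)[C@H]3O)c2n1`) gives > 20000 nM and this is a limit of the assay, not a number. Compound 2 (`Nc1nc(N)c2c(-c3cccs3)cn([C@@H]3O[C@H](CO)[C@@H](O)[C@H]3O)c2n1`) gives > 20000 nM and this too is a limit. Compound 1 (`Cc1ncnc2c1c(-c1ccoc1)cn2[C@@H]1O[C@H](CO)[C@@H](O)[C@H]1O`) gives > 20000 nM and this is again a limit. Every measured compound therefore sits at the same ceiling (the limit of > 20000 nM in this assay, at which 3 of the 3 values shown sit).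

Compound 4 (`C#Cc1cn([C@@H]2O[C@H](CO)[C@@H](O)[C@H]2O)c2nc(C)nc(N)c12`) keeps the core of compound 3 but carries ethynyl in place of thiophen-2-yl on an aromatic carbon. Within the data shown here, the only measured step (a step that the two limits leave unreadable from compound 2 to compound 3) concerns a different change and has no readable size, so it offers no size to carry over. Among the measured compounds shown here, no measured pair tests this swap. The likeliest outcome in this assay is that no clear step appears, with a smaller chance of a readable value on the side of stronger inhibition. The estimated change is small and uncertain (an at least 1.4-fold lower number from compound 3 to compound 4 (0.15 log units; that floor lies within the scatter)). Compound 4 is estimated at 14000 nM (expected range 2000 nM to 30000 nM).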

Compound 4, half-maximal inhibitory concentration: > 20000 nM
Compound 4: only a limit was reported; the forecaster's own chance of this, stated with the estimate: 65%; middle value at least 1.4-fold (0.15 log units) away from the limit.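

In this assay, compound 3 and compound 4 each give only a limit, so no step between them can be read: the limit of > 20000 nM in this assay, at which 4 of the 4 values shown sit.

The compounds shown leave open how strongly any of them inhibits, and whether ethynyl and thiophen-2-yl differ at all in their effect.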